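Dimethylamino for amino in a small amide series

The compounds below may be only part of what the source reports. "The series", "measured", "known", "first", "only" and "open" are said of these compounds alone.

In a functional assay on the whole organism (strain NMRI) with Mus musculus as the target, with a stated time of 30 min (on this read-out higher numbers stand for an effect only at larger amounts of compound and lower numbers for an effect already at smaller amounts), compound 1, the structure `CCC(C)C(N)C(=O)NCc1ccccc1`, gives > 120 mg/kg. That figure is a limit of this assay rather than a number, and it is where the limit of > 120 mg/kg in this assay, at which 1 of the 2 values shown sits, places the only reported result. Compound 2, the structure `NCC(N)C(=O)NCc1ccccc1`, has "not determined" (no result reported) in this assay, so no number sets where compound 2 stands. For the measured compounds named here, the only value shown anywhere in the set is the one reported for compound 1. Compound 3, the structure `CN(C)CC(N)C(=O)NCc1ccccc1`, has not been tested. It differs from compound 2 by dimethylamino in place of amino on a saturated chain carbon, two bonds along the chain from an amine nitrogen and a carbonyl carbon. Going by the values given here, with no measured step between any two compounds, there is no basis to expect a step beyond the usual scatter in this assay in either direction, and the single limit of compound 1 suggests that a limit is the likeliest outcome again. Compound 3 is therefore estimated at 120 mg/kg in this assay, within a range from 40 mg/kg to 400 mg/kg.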

Compound 3, dose for half-maximal effect: > 110 mg/kg
Compound 3: no number, only a limit; the forecaster's own chance of this, stated with the estimate: 70%; the middle value is on the limit's open side.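

For the compounds shown here, compound 1 and compound 3 each carry only a limit of the assay rather than a number, so no step between them can be read. Still open, as far as these compounds go, is what dose of either compound gives a half-maximal effect in this assay, and what dimethylamino in place of amino does to that dose.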